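This account rests on a few compounds, and the source may have more. Where it says the series, first, only, none or still open, it means among the compounds named here.

Measured so far:
Compound 1 `Cc1oc(-c2c(C)c(C)c(C)c(C)c2C)nc1CN1CCC(C(=O)NCCCN2C[C@H](C)C[C@H](C)C2)CC1`: 8180 nM in an ADME assay on Huh7.5.1 cells (Homo sapiens) for cytotoxicity, read by ATP content, with a stated time of 48 h; on this read-out higher numbers stand for lower toxicity in this test and lower numbers for higher toxicity in this test
Compound 2 `Cc1ccccc1-c1nc(CN2CCC(C(=O)NCCCCN3C[C@H](C)C[C@H](C)C3)CC2)c(C)o1`: 23100 nM in this assay

Among these two numbers compound 1 stands lowest, and the gap up to compound 2 lies beyond the usual scatter, so compound 1 is the more toxic of the pair in this assay. The next compound to consider is compound 3 `Cc1ccc(-c2nc(CN3CCC(C(=O)NCCCN4C[C@H](C)C[C@H](C)C4)CC3)c(C)o2)cc1`, which has not yet been measured. It keeps the core of compound 1 and differs in one place: 4-methylphenyl in place of 2,3,4,5,6-pentamethylphenyl on an aromatic carbon. Among the compounds with values here, no pair of measured compounds shows this kind of swap, so there is no step to lean on, and the expectation rests on the general run of the two numbers seen so far. The step from compound 1 to compound 3 in this assay is expected to be a 1.7-fold higher number from compound 1 to compound 3 (0.23 log units; within the scatter), a modest move toward a higher number, not far beyond the scatter. Compound 3 is estimated at 14000 nM, with a range from 5000 nM to 40000 nM.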

Compound 3, half-maximal cytotoxic concentration: 4330 nM
Compound 3: middle estimate off by 3.2-fold (0.51 log units), on the high side; the measured number lies below the stated range.
By their numbers in this assay, from the lowest: compounds 3 and 1 (each within the scatter of the next); then compound 2.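

In this assay, putting 4-methylphenyl in place of 2,3,4,5,6-pentamethylphenyl on this aromatic carbon gives a 1.9-fold lower number from compound 1 to compound 3 (0.28 log units; within the scatter), so the two compounds cannot be told apart in this test. The group shrinks from 11 heavy atoms to 7, yet the number stays within what repeat measurements could produce, which means that, for this pair, the added methyl groups of the larger ring make no clear difference to the read-out. Nothing available here explains this result.

Compound 2 differs from both compound 1 and compound 3 in more than one place, so its higher number cannot be assigned to any single change. Also open, from the compounds shown here alone, is whether a phenyl ring carrying an amine or a carboxylic acid at this position would move the number beyond the scatter.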